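Changing the Aryl Group on the Ring Nitrogen

This account rests on a few compounds, and the source may have more. Where it says the series, first, only, none or still open, it means among the compounds named here.

Compound 1, `Cc1cc(=O)n(-c2ccccc2C(F)(F)F)nc1C(=O)Nc1ccc(Oc2ncnc3c2ccn3C)cc1`, gives 27200 nM in a functional assay on HepG2 cells (Homo sapiens) for cytotoxicity, read by MTT assay, with a stated time of 72 h; a higher number here means a weaker inhibitor, a lower number a stronger inhibitor.
Compound 2, `Cc1cc(=O)n(-c2ccc(Br)cc2F)nc1C(=O)Nc1ccc(Oc2ncnc3c2ccn3C)c(F)c1`, gives > 60000 nM in this assay.
Compound 3, `Cc1ccc(-n2nc(C(=O)Nc3ccc(Oc4ncnc5c4ccn5C)c(F)c3)c(C)cc2=O)cc1`, gives > 60000 nM in this assay.

Compound 3 stands only at a limit in this assay: its reading > 60000 nM is a limit of the assay and not a number. Within the data shown here, the single measured step that reaches it, a step that the two limits leave unreadable from compound 2 to compound 3, cannot be read in size because both of its ends sit at the limit of > 60000 nM in this assay, at which 2 of the 3 values shown sit. Among the measured compounds shown here, no other measured step touches the group on the ring nitrogen, so the data give no readable step for this position.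

Compound 4, `Cc1cc(=O)n(-c2ccccc2C(F)(F)F)nc1C(=O)Nc1ccc(Oc2ncnc3c2ccn3C)c(F)c1`, has not yet been measured. It differs from compound 3 in one place: 2-(trifluoromethyl)phenyl in place of 4-methylphenyl on an aromatic nitrogen. Compound 1 carries this same 2-(trifluoromethyl)phenyl on the ring nitrogen, and compound 1 gives 27200 nM in this assay, a number rather than a limit. For the measured compounds named here, no measured step links compound 1 to compound 4, so only that value is available as a pointer.

The step of an at least 1.7-fold lower number from compound 3 to compound 4 (0.23 log units; that floor lies within the scatter) is therefore expected to start from a limit and cannot be sized. Compound 4 is expected to come in near 35000 nM, within 12000 nM to 80000 nM.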

Compound 4, half-maximal inhibitory concentration: > 60000 nM
Compound 4: no number, only a limit; the forecaster's own chance of this, stated with the estimate: 40%; at least 1.7-fold (0.23 log units) between middle value and limit.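

In this assay the reading of compound 4 is a limit and not a number. Even so, fluoro in place of hydrogen on an aromatic carbon, with the 2-(trifluoromethyl)phenyl group kept on the ring nitrogen, gives an at least 2.2-fold higher number from compound 1 to compound 4 (0.34 log units; beyond the scatter), so the fluoro change on the other side of the molecule, not a change of aryl group, provides the only step with a readable lower bound so far. The steps among compound 2, compound 3 and compound 4 cannot be read, because all three compounds sit at the same limit: the limit of > 60000 nM in this assay, at which 3 of the 4 values shown sit.

The compounds shown therefore leave open how much the aryl group on the ring nitrogen matters once the fluoro is present, and whether the fluoro step would look the same with a different aryl group. Also open, going by these compounds, is whether a phenyl ring carrying an amine or a carboxylic acid on the ring nitrogen would give a true number in this assay with the fluoro in place.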